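A few compounds are considered here, and "the series" means these few. Any claim that something is new, unique, unknown or untested is made for them only; others in the source may bear on it.

Series notes on cytotoxicity. Compound 1 `CCCSc1nc(N)nc2c1ncn2/C=C1/CC1(CO)CO` in an ADME assay on Akata cells (Homo sapiens) for cytotoxicity, with a stated time of 7 days (on this read-out lower numbers stand for higher toxicity in this test and higher numbers for lower toxicity in this test), gives only a limit of the assay and not a number, > 20000 nM. Compound 2 `Nc1nc(OCC(F)(F)F)c2ncn(/C=C3/CC3(CO)CO)c2n1` in this assay likewise gives only a limit, > 20000 nM. Compound 3 `Nc1nc2c(ncn2/C=C2/CC2(CO)CO)c(=O)[nH]1` in this assay also gives only a limit, > 20000 nM. The step from compound 1 to compound 2 in this assay is a step that the two limits leave unreadable from compound 1 to compound 2; with 2,2,2-trifluoroethoxy in place of propylsulfanyl on an aromatic carbon, the two limits leave its size unreadable. Compound 2 thus stands where every measured member of the set stands, at the limit of > 20000 nM in this assay, at which 3 of the 3 values shown sit, without a number of its own.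

Compound 4 `C=CCOc1nc(N)nc2c1ncn2/C=C1/CC1(CO)CO` is not yet measured in this assay. Relative to compound 2 the change is vinyl in place of trifluoromethyl on a saturated chain carbon bound to an oxygen on an aromatic ring. For the measured compounds named here, no measured step covers this exchange, and the single step in the set, the one from compound 1 to compound 2, is itself unreadable. Since compounds 1, 2 and 3 all sit at the limit of > 20000 nM in this assay, at which 3 of the 3 values shown sit, the expectation for this assay is no step beyond the scatter and, most likely, another limit. Compound 4 is therefore expected at 40000 nM, with a range from 15000 nM to 150000 nM. The expected step from compound 2 to compound 4 is a step that the limit leaves unreadable from compound 2 to compound 4, with a high chance that the assay again reports only its limit.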

Compound 4, half-maximal cytotoxic concentration: > 20000 nM
Compound 4: no number, only a limit; the forecaster's own chance of this, stated with the estimate: 85%; the middle value lies beyond the limit too.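

No new step can be read for compound 4 against compound 1 or compound 2, since each pair offers only limits and no numbers: (the limit of > 20000 nM in this assay, at which 4 of the 4 values shown sit). The compounds shown leave open whether any change at the group on the aromatic carbon alters the read-out in this assay and where any member of the series would give a number.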